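Working notes on compounds 1 to 4

A few compounds are considered here, and "the series" means these few. Any claim that something is new, unique, unknown or untested is made for them only; others in the source may bear on it.

The series is followed in a functional assay on the whole organism (stomach) for inhibition, with Rattus norvegicus as the target, with a stated time of 4 h; a lower number here means that less compound is needed, a higher number that more compound is needed for the effect. Compound 1 `C/N=C(\NC#N)NCCSCn1nc(-c2ccccc2)ccc1=O` gives only a limit in this assay, < 30.5 mg/kg. Compound 2 `CC/N=C(\NC#N)NCCSCn1nc(-c2ccccc2)ccc1=O` likewise gives only a limit, < 100 mg/kg. Compound 3 `CC/N=C(\NC#N)NCCSCCn1nc(-c2ccccc2)ccc1=O` also gives only a limit, < 100 mg/kg. Compound 4 `CCC/N=C(\NC#N)NCCSCCn1nc(-c2ccccc2)ccc1=O` has not yet been measured in this assay.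

From compound 1 to compound 2 the change is methyl in place of hydrogen on a saturated chain carbon bound to a double-bonded nitrogen. The step that the two limits leave unreadable from compound 1 to compound 2 cannot be read, since both ends are limits; what the measured values show is the limit of < 100 mg/kg in this assay, at which 2 of the 3 values shown sit, and (the limit of < 30.5 mg/kg in this assay, at which 1 of the 3 values shown sits), and nothing more. The difference between the core of compound 1 and the core of compound 3 is not broken down here.

From compound 3 to compound 4 the change is methyl in place of hydrogen on a saturated chain carbon, two bonds along the chain from a double-bonded nitrogen. This is the same kind of change as from compound 1 to compound 2, though not the same: there the place is on a saturated chain carbon bound to a double-bonded nitrogen, here it is on a saturated chain carbon, two bonds along the chain from a double-bonded nitrogen. Beside that unreadable earlier step, the step expected in this assay is a step that the limit leaves unreadable from compound 3 to compound 4, a size chosen to stay within the usual scatter, because the only anchor for compound 3 is the limit < 100 mg/kg and no measured step of this kind can be read. Compound 4 is expected in this assay at 50 mg/kg, within 12 mg/kg to 150 mg/kg, with a fair chance that only a limit is reported again.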

Compound 4, dose for half-maximal effect: > 100 mg/kg
Compound 4 was reported as a limit; the forecaster's own chance of this, stated with the estimate: 60%; middle value at least 2.0-fold (0.30 log units) from the limit.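

In this assay compound 4 is reported only as a limit, > 100 mg/kg. Set against the limit of compound 3, the new step is a number no lower from compound 3 to compound 4 (the limit leaves the size open); this shows that, on the core of compound 3, methyl in place of hydrogen on a saturated chain carbon, two bonds along the chain from a double-bonded nitrogen, gives no lower number in this assay, but it gives no size for that step. It does not show whether the change carries from one core to another, since the earlier step of the same kind, on the core of compound 1, cannot be read, that step sits at a different place on the chain, and the values shown offer only limits: the limit of > 100 mg/kg in this assay, at which 1 of the 4 values shown sits.

Going by these compounds, the numbers behind all the limits remain open, as does what propyl in place of ethyl would give on the core of compound 1. Also open, on these data alone, is how a longer chain than propyl, or an amine or a carboxylic acid carried at the end of that chain, would read in this assay on either core.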